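A urea replaces a thiourea on the ring amine nitrogen

The compounds below may be only part of what the source reports. "The series", "measured", "known", "first", "only" and "open" are said of these compounds alone.

The measured compounds, with their values in a functional assay on MKN-74 cells (Homo sapiens) for antiproliferative activity, with a stated time of 24 h; a higher number here means a weaker inhibitor, a lower number a stronger inhibitor:
- compound 1, `NC(=O)c1c(NC(=O)c2ccccc2Cl)sc2c1CCN(Cc1ccccc1Cl)C2`: 4430 nM
- compound 2, `NC(=O)c1c(NC(=O)c2ccccc2Cl)sc2c1CCN(Cc1ccc(Cl)cc1)C2`: 18700 nM
- compound 3, `Cc1ccccc1NC(=S)N1CCc2c(sc(NC(=O)c3ccccc3Cl)c2C(N)=O)C1`: 11700 nM

Among these three numbers compound 3 holds the second highest. Its nearest neighbour is compound 2, and a 1.6-fold lower number from compound 2 to compound 3 (0.20 log units; within the scatter); its furthest is compound 1, and a 2.6-fold higher number from compound 1 to compound 3 (0.42 log units; beyond the scatter). Compound 4, `NC(=O)c1c(NC(=O)c2ccccc2Cl)sc2c1CCN(C(=O)Nc1c(Cl)cccc1Cl)C2`, keeps the shared core and differs from compound 3 only at the ring amine nitrogen: a group of 11 heavy atoms (7 carbon, 1 nitrogen, 1 oxygen, 2 chlorine; one six-membered aromatic ring of carbon only) in place of a group of 10 heavy atoms (8 carbon, 1 nitrogen, 1 sulfur; one six-membered aromatic ring of carbon only), on an amine nitrogen in a ring.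

For the measured compounds named here, two measured steps touch the same position. Both the move from compound 1 to compound 3 and the move from compound 1 to compound 2 changed only the group on that nitrogen, and the shifts were modest: a 4.2-fold higher number from compound 1 to compound 2 (0.63 log units; beyond the scatter), a 2.6-fold higher number from compound 1 to compound 3 (0.42 log units; beyond the scatter). The move from compound 2 to compound 3 stayed within the scatter. Nothing measured here carries a carbamoyl group or a dichlorophenyl at this nitrogen, so the direction of the new step is not fixed by the data.

Compound 4 is therefore expected to land close to compound 3, with a step of about a 1.5-fold lower number from compound 3 to compound 4 (0.17 log units; within the scatter), which is within the scatter or only modestly beyond it. The estimate for compound 4 in this assay is 8000 nM, with a range from 2500 nM to 25000 nM.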

Compound 4, half-maximal inhibitory concentration: 24400 nM
The estimate for compound 4 lay 3.1-fold (0.48 log units) below the measured number; the range from low to high includes it.
By their numbers in this assay, from the lowest: compound 1; then compounds 3, 2 and 4 (each within the scatter of the next, the first and the last beyond it).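

In this assay the (2,6-dichlorophenyl)carbamoyl group on the amine nitrogen in a ring brings no gain over the group it replaces, with a 2.1-fold higher number from compound 3 to compound 4 (0.32 log units; beyond the scatter) as the result of the exchange, and set against 4-chlorobenzyl it gives a 1.3-fold higher number from compound 2 to compound 4 (0.12 log units; within the scatter) so that these two groups cannot be told apart in this assay. The position therefore accepts this larger carbamoyl group without any improvement, and 2-chlorobenzyl keeps the lowest number of the four compounds, as a 5.5-fold higher number from compound 1 to compound 4 (0.74 log units; beyond the scatter) shows for the widest gap in the set. No measurement is available that would account for these shifts.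

The exchange from compound 3 to compound 4 alters both the sulfur-bearing link and the aromatic ring at once, so a (2,6-dichlorophenyl)thiocarbamoyl group or an unsubstituted phenylcarbamoyl group would be needed to separate the two changes. From the compounds shown here alone, whether a benzyl group carrying a second chlorine, or one carrying a carboxylic acid or an amine in place of chlorine, would improve on compound 1, which gives 4430 nM, also stays open.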